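A few compounds are considered here, and "the series" means these few. Any claim that something is new, unique, unknown or untested is made for them only; others in the source may bear on it.

Compound 3, `CC(C)(C)Cc1c(-c2ccccc2)sc(N)c1C(=O)c1cccc(C(F)(F)F)c1`, is the starting point of this step. In an assay on CHO cells for displacement of a labelled ligand from adenosine receptor A3 (Homo sapiens), read by scintillation counting, tested at 10 uM (on this read-out higher numbers stand for more inhibition at the one concentration tested (going by the name of the read-out) and lower numbers for less inhibition), compound 3 gives 1%. It stands level, at the digits shown, with compound 1, `Cc1csc(N)c1C(=O)c1ccc(Cl)cc1`, which in this assay gives 1%; the gap between the two is no change at the digits shown and within the scatter. Compound 2, `CC(C)(C)Cc1c(-c2ccccc2)sc(N)c1C(=O)c1cccc(Cl)c1`, gives 5% in this assay, and the difference to compound 3 is also within the scatter. Among the compounds with values here, the one measured step that leads to compound 3 is the one from compound 2, which reads a number 4 percentage points lower from compound 2 to compound 3 (within the scatter), again within the scatter.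

Compound 4, `COc1ccc(-c2sc(N)c(C(=O)c3cccc(C(F)(F)F)c3)c2CC(C)(C)C)cc1`, differs from compound 3 by methoxy in place of hydrogen on an aromatic carbon. Within the data shown here, no measured step involves a methoxy, so nothing bears directly on this change. Among the measured compounds shown here, what the three measured compounds do show is that every difference among them, including the only step, lies within the scatter. The step from compound 3 to compound 4 is therefore expected to be a number 2 percentage points higher from compound 3 to compound 4 (within the scatter), nothing beyond the scatter. For compound 4 the estimated value in this assay is 3%, with an expected range from -6% to 15%.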

Compound 4, a percentage reported as inhibition, at one concentration (the size of the read-out at that concentration, not a potency): 1%
Compound 4: the middle estimate sits 2 percentage points above what was measured; measured number inside the range.
By their numbers in this assay, from the lowest: compounds 1, 3, 4 and 2 (each within the scatter of the next).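

In this assay, the change of phenyl to 4-methoxyphenyl reads no change at the digits printed from compound 3 to compound 4 (within the scatter), which gives the first measured result for a substitution on an aromatic carbon para to a large group. Within the data shown here, the one earlier step, a number 4 percentage points lower from compound 2 to compound 3 (within the scatter), exchanged chloro for trifluoromethyl at a different place, so it said nothing about this position; here, adding methoxy leaves the read-out within the scatter. Nothing available accounts for this result, and no measurement bears on why the number stays where it does.

With only this one substituent tested at this position, the compounds shown leave open whether another group there, such as a hydroxy, an amine, a carboxylic acid or a longer alkoxy chain, would move the read-out beyond the scatter. They also leave open whether methoxy would read the same when combined with chloro in place of trifluoromethyl, as in compound 2, or when placed elsewhere on the same six-membered aromatic ring.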